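The source may hold more compounds than are shown below. What is called first, only, known or untested is meant among the compounds shown, and "the series" means these compounds.

Measured so far in a functional assay on SW480 cells (Homo sapiens) for inhibition, read by MTT assay, with a stated time of 72 h; a lower number here means a stronger inhibitor of growth, a higher number a weaker inhibitor of growth:

Compound 1, `N#C/C(=C\c1ccc(Cl)cc1)C(=O)c1ccc[nH]1`: 34000 nM
Compound 2, `COc1ccc(CNC(=O)/C(C#N)=C/c2ccc(C)o2)cc1`: 29000 nM

Both measured compounds share a chain in which a nitrile and an aromatic ring sit on the two carbons of a double bond, and both are weak inhibitors of growth in this assay. Among the two numbers, compound 2 stands beside compound 1: the two values lie within the usual scatter of each other, so neither can be called the stronger or weaker growth inhibitor on this evidence.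

The next compound, compound 3, `COc1ccc(CNC(=O)/C(C#N)=C/c2ccc(Cl)cc2)cc1`, keeps the amide end of compound 2 and changes the aromatic ring on the chain: 4-chlorophenyl in place of 5-methylfuran-2-yl on a double-bonded chain carbon bound to a double-bonded chain carbon. Compound 1 already carries the 4-chlorophenyl ring on the same kind of chain, with a different group at the other end, and its value in this assay sits close to that of compound 2. Within the data shown here, no step between two compounds that differ only in this ring has been measured, so there is no direct guide to its size. The expectation for compound 3 is therefore a step of a 1.0-fold higher number from compound 2 to compound 3 (0.01 log units; within the scatter), that is, nothing beyond the scatter in either direction. Compound 3 is expected to give about 30000 nM in this assay, within a range from 12000 nM to 80000 nM.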

Compound 3, concentration for 50% growth inhibition: 10000 nM
Estimate against measurement, compound 3: 3.0-fold (0.48 log units) above, outside the stated range (below it).
By their numbers in this assay, from the lowest: compound 3; then compounds 2 and 1 (each within the scatter of the next).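

In this assay, the ring on a double-bonded chain carbon bound to a double-bonded chain carbon now proves able to shift the result: with the amide end held fixed, 4-chlorophenyl in place of 5-methylfuran-2-yl gives a 2.9-fold lower number from compound 2 to compound 3 (0.46 log units; beyond the scatter), a modest step but one beyond the scatter. The earlier pair could not show this, since compound 1 and compound 2 differ in more than one place, whereas compound 2 and compound 3 differ only in this ring. The swap still changes several things at once, replacing a five-membered aromatic ring with one hetero atom and a methyl group by a six-membered carbon ring bearing chlorine, and nothing measured here explains the step.

From the compounds shown here alone, it remains open whether the chlorine or the six-membered ring carries the step, a question that a plain phenyl ring or a 5-chlorofuran-2-yl ring at this position would address. Going by these compounds, it is also open whether the same ring change would give a similar step with a different group at the amide end, such as a longer carbon chain.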